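Swapping the Chain Terminus: A Forecast for Compound 4

The compounds below may be only part of what the source reports. "The series", "measured", "known", "first", "only" and "open" are said of these compounds alone.

Compound 2 `C/N=C(\S)NCCCn1nc(-c2ccccc2)ccc1=O` was examined in a functional assay on the whole organism (stomach) with Rattus norvegicus as the target; on this read-out lower numbers stand for an effect already at smaller amounts and higher numbers for an effect only at larger amounts of compound. In this assay compound 2 reaches only the limit of > 100 mg/kg, a boundary of the test rather than a number. Two other compounds share its core. Compound 1 `C/N=C(/NC#N)NCCCCn1nc(-c2ccc(Cl)cc2)ccc1=O` gives 100 mg/kg in this assay. Compound 3 `C/N=C(/NC#N)NCCCCn1nc(-c2ccccc2)c(C)cc1=O` likewise stops at the limit of > 100 mg/kg in this assay. The overall picture is the limit of > 100 mg/kg in this assay, at which 2 of the 3 values shown sit. Compound 4 `CN(C)/C(=N/CCCn1nc(-c2ccccc2)ccc1=O)NC#N` differs from compound 2 by a group of 8 heavy atoms (4 carbon, 4 nitrogen; no ring) in place of a group of 5 heavy atoms (2 carbon, 2 nitrogen, 1 sulfur; no ring), on a saturated chain carbon, three bonds along the chain from an aromatic nitrogen. Within the data shown here, no step between measured compounds sizes this change, so the expectation is for no shift beyond the scatter, and the step of a number no higher from compound 2 to compound 4 (the limit leaves the size open) is expected to be small. Compound 4 is therefore estimated at 100 mg/kg, within 50 mg/kg to 200 mg/kg.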

Compound 4, dose for half-maximal effect: 53 mg/kg
Beside the measured number, compound 4's estimate is 1.9-fold (0.28 log units) above it, within the range that was stated.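

The exchange on the saturated chain carbon, three bonds along the chain from an aromatic nitrogen, yields a measurable number in this assay, with an at least 1.8-fold lower number from compound 2 to compound 4 (0.27 log units; that floor lies within the scatter). Among these compounds, this is the first step read at this position, and it shows that the position tolerates the larger group without the effect being lost. The wider series still sits largely at the edge of the test: the limit of > 100 mg/kg in this assay, at which 2 of the 4 values shown sit.

Going by these compounds, the true size of the step remains open, since compound 2 has only a limit. Also open, on these data alone, is how a primary amine or a carboxylic acid at this position would read.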